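From carboxy to methoxycarbonyl: compound 3 to compound 4

A few compounds are considered here, and "the series" means these few. Any claim that something is new, unique, unknown or untested is made for them only; others in the source may bear on it.

In a functional assay on AGS cells (Homo sapiens) for inhibition, read by MTT assay, with a stated time of 72 h (on this read-out lower numbers stand for stronger inhibition and higher numbers for weaker inhibition), compound 1 (`CC(=O)Oc1cc(C(=O)C2=C(O)[C@]3(CC=C(C)C)C[C@@H](C/C=C(\C)CCC=C(C)C)[C@](C)(CCC=C(C)C)[C@](CC=C(C)C)(C2=O)C3=O)ccc1O`) gives 8090 nM and compound 2 (`CC(=O)Oc1ccc(C(=O)C2=C(O)[C@]3(CC=C(C)C)C[C@@H](C/C=C(\C)CCC=C(C)C)[C@](C)(CCC=C(C)C)[C@](CC=C(C)C)(C2=O)C3=O)cc1OC(C)=O`) gives 15700 nM as numbers on the shared core. Compound 3 (`CC(C)=CCC/C(C)=C/C[C@@H]1C[C@]2(CC=C(C)C)C(=O)[C@@](CC=C(C)C)(C(=O)C(C(=O)c3ccc(OCC(=O)O)c(OCC(=O)O)c3)=C2O)[C@@]1(C)CCC=C(C)C`) gives > 20000 nM as a limit of the assay and not a number. Going by the values given here, its standing is the limit of > 20000 nM in this assay, at which 1 of the 3 values shown sits, and no exact step can start from it.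

Compound 4 (`COC(=O)COc1ccc(C(=O)C2=C(O)[C@]3(CC=C(C)C)C[C@@H](C/C=C(\C)CCC=C(C)C)[C@](C)(CCC=C(C)C)[C@](CC=C(C)C)(C2=O)C3=O)cc1OCC(=O)O`) carries this difference: methyl in place of hydrogen on an oxygen next to a carbonyl group as methyl in place of hydrogen on an oxygen next to a carbonyl group, which also reads as carboxymethyl to (methoxycarbonyl)methyl.

Among the compounds with values here, the one measured step is a 1.9-fold higher number from compound 1 to compound 2 (0.29 log units; within the scatter) for acetyl in place of hydrogen on an oxygen on an aromatic ring. It is a different change at a different place and bears only loosely on this one. Within the data shown here, with only that step as a guide, no size beyond the scatter and no direction is expected, and the estimated step is an at least 1.1-fold lower number from compound 3 to compound 4 (0.04 log units; that floor lies within the scatter) in this assay on this reading. For compound 4 the estimate is 18000 nM with an expected range from 8000 nM to 40000 nM and a fair chance of another limit.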

Compound 4, half-maximal inhibitory concentration: > 20000 nM
Compound 4 gave a limit, no number; the forecaster's own chance of this, stated with the estimate: 50%; at least 1.1-fold (0.04 log units) between middle value and limit.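

Compound 3 and compound 4 both stand at a limit and not at a number, so no step can be read between them: the limit of > 20000 nM in this assay, at which 2 of the 4 values shown sit.

Going by these compounds, whether methyl in place of hydrogen on an oxygen next to a carbonyl group changes the read-out at all, and in which direction, stays open.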